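The source may hold more compounds than are shown below. What is called first, only, known or untested is meant among the compounds shown, and "the series" means these compounds.

In an ADME assay on HepG2 2.2.15 cells (Homo sapiens) for cytotoxicity (on this read-out higher numbers stand for lower toxicity in this test and lower numbers for higher toxicity in this test), the series so far reads:
- compound 1 `O=CCc1c(-c2ccccc2Cl)c2cc(Cl)ccc2[nH]c1=O` gives 120000 nM
- compound 2 `CCCC(=O)OCCc1c(-c2ccccc2Cl)c2cc(Cl)ccc2[nH]c1=O` gives 52000 nM
- compound 3 `CCCCC(=O)OCCc1c(-c2ccccc2Cl)c2cc(Cl)ccc2[nH]c1=O` has no measurement yet

In this assay compound 2 holds the lower of the two numbers. The change to compound 3 (methyl in place of hydrogen on a saturated chain carbon, three bonds along the chain from a carbonyl carbon) is methyl in place of hydrogen on a saturated chain carbon, three bonds along the chain from a carbonyl carbon; cut further out, it reads propyl to butyl. For the measured compounds named here, only one measured step bears on this, and only loosely: a 2.3-fold lower number from compound 1 to compound 2 (0.36 log units; beyond the scatter) is modest, and it is a different and larger replacement, ((propylcarbonyl)oxy)methyl in place of formyl. The expected move, a 1.1-fold lower number from compound 2 to compound 3 (0.05 log units; within the scatter) in this assay, is estimated to stay within the scatter, if anything towards a slightly lower number. Compound 3 is expected at 46000 nM, with an estimated range from 23000 nM to 92000 nM.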

Compound 3, half-maximal cytotoxic concentration: 200000 nM
For compound 3 the middle estimate is 4.3-fold (0.64 log units) below the measured one; measured number outside the range, above it.
By their numbers in this assay, from the lowest: compound 2; then compounds 1 and 3 (each within the scatter of the next).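

In this assay a single methyl in place of hydrogen on a saturated chain carbon, three bonds along the chain from a carbonyl carbon, gives a 3.8-fold higher number from compound 2 to compound 3 (0.59 log units; beyond the scatter) and shows that even the small change from propyl to butyl can move the number beyond the scatter. Replacing formyl with ((butylcarbonyl)oxy)methyl gives a 1.7-fold higher number from compound 1 to compound 3 (0.22 log units; within the scatter) and so leaves no separation on this read-out, unlike the replacement with ((propylcarbonyl)oxy)methyl. Nothing on hand bears on the reason for this step.

As far as these compounds go, whether the move from propyl to butyl belongs to a trend with chain length or stands as a single jump stays open. From the compounds shown here alone, what a longer chain such as hexyl, or an amine or a carboxylic acid in place of the butyl chain, would do here also stays open.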